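Adding a Second Propyl to a Biaryl Benzylamine

This account rests on a few compounds, and the source may have more. Where it says the series, first, only, none or still open, it means among the compounds named here.

Compound 1 `CCNCc1ccc(Cl)c(-c2ccccc2OC)c1`: 210 nM
Compound 2 `CCCNCc1ccc(Cl)c(-c2ccccc2OC)c1`: 640 nM

In an assay on isolated protein for binding affinity to 5-hydroxytryptamine receptor 1B (Homo sapiens) (on this read-out lower numbers stand for stronger inhibition and higher numbers for weaker inhibition), compound 1 gives 210 nM and compound 2 gives 640 nM, the highest of the two numbers. Among the compounds with values here, the one measured step, a 3.0-fold higher number from compound 1 to compound 2 (0.48 log units; beyond the scatter), came from methyl in place of hydrogen on a saturated chain carbon, two bonds along the chain from an amine nitrogen. Compound 3 `CCCN(CCC)Cc1ccc(Cl)c(-c2ccccc2OC)c1` differs from compound 2 by propyl in place of hydrogen on an amine nitrogen, propylamino becoming dipropylamino. Within the data shown here, that earlier step is the only guide: more carbon near this amine raised the number, so a further modest rise, a 2.3-fold higher number from compound 2 to compound 3 (0.37 log units; beyond the scatter), is expected. Compound 3 is estimated at 1500 nM, between 500 nM and 5000 nM.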

Compound 3, inhibition constant: > 10000 nM
Compound 3: no number, only a limit (the forecaster's own chance of this, stated with the estimate: 10%); at least 6.6-fold (0.82 log units) between middle value and limit.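

In this assay compound 3 gives > 10000 nM as a limit of the assay, not a number: the limit of > 10000 nM in this assay, at which 1 of the 3 values shown sits. Propyl in place of the hydrogen on the amine nitrogen brings an at least 15-fold higher number from compound 2 to compound 3 (1.19 log units; beyond the scatter), and the whole change to dipropylamino brings an at least 47-fold higher number from compound 1 to compound 3 (1.67 log units; beyond the scatter). Among these three compounds, a second chain on the nitrogen therefore weighs far more than lengthening the single chain did.

From the compounds shown here alone, whether a methyl as the second group on the nitrogen would cost as much stays open. So does the reading of the primary amine, with no chain on the nitrogen.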